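This account rests on a few compounds, and the source may have more. Where it says the series, first, only, none or still open, it means among the compounds named here.

Compound 1, `C[C@@H](O[C@@H]1CN(C=O)C[C@H]1c1ccc(F)cc1)c1cc(C(F)(F)F)cc(C(F)(F)F)c1`, gives 0.24 nM in an assay on CHO cells for displacement of a labelled ligand from Substance-P receptor (Homo sapiens); a lower number here means a stronger inhibitor, a higher number a weaker inhibitor.
Compound 2, `C[C@@H](O[C@@H]1CN(C(=O)NC(C)(C)C)C[C@H]1c1ccc(F)cc1)c1cc(C(F)(F)F)cc(C(F)(F)F)c1`, gives 0.14 nM.

In this assay compound 2 stands level with compound 1, since a 1.7-fold lower number from compound 1 to compound 2 (0.23 log units; within the scatter) lies within the scatter. Compound 3, `C[C@@H](O[C@@H]1CN(C(=O)NCc2cn[nH]n2)C[C@H]1c1ccc(F)cc1)c1cc(C(F)(F)F)cc(C(F)(F)F)c1`, differs from compound 2 by (2H-1,2,3-triazol-4-yl)methyl in place of tert-butyl on an amide-type nitrogen. Among the compounds with values here, the only measured step, a 1.7-fold lower number from compound 1 to compound 2 (0.23 log units; within the scatter), concerns the carbonyl substituent, not the group on the amide-type nitrogen, so no direct precedent for the replacement exists. Compound 3 is therefore expected to stay close to compound 2, with a change of a 2.1-fold higher number from compound 2 to compound 3 (0.33 log units; beyond the scatter), and its estimated value is 0.3 nM, within a range from 0.08 nM to 1.2 nM.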

Compound 3, half-maximal inhibitory concentration: 0.58 nM
Compound 3: middle estimate off by 1.9-fold (0.29 log units), on the low side; measured number inside the range.
By their numbers in this assay, from the lowest: compounds 2 and 1 (each within the scatter of the next); then compound 3.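

Within the data shown here, replacing tert-butyl with (2H-1,2,3-triazol-4-yl)methyl on the amide-type nitrogen produces the first step beyond the scatter in this assay, with a 4.1-fold higher number from compound 2 to compound 3 (0.62 log units; beyond the scatter). Against hydrogen on the carbonyl carbon, ((2H-1,2,3-triazol-4-yl)methyl)amino gives a 2.4-fold higher number from compound 1 to compound 3 (0.38 log units; beyond the scatter), so both steps are modest and this position accepts a five-membered aromatic ring at a limited cost. Going by these compounds, whether a phenyl ring, a carboxylic acid or a simple methyl group on this nitrogen would match compound 2 remains open. Nothing available accounts for the size of these steps.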